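Adding methoxy to a compound at the assay limit

The source may report more compounds than this note shows. Statements on the series, on what has been measured and on what is new or still open speak of the compounds shown alone.

Compound 1 `Clc1cc2nc(Cl)n(Cc3ccccc3)c2cc1Cl`: > 100000 nM
Compound 2 `COc1ccc(Cn2c(Cl)nc3cc(Cl)c(Cl)cc32)cc1`: > 100000 nM
Compound 3 `Clc1cc2nc(Br)n(Cc3ccccc3)c2cc1Cl`: > 100000 nM

All three entries are limits of the assay, not numbers. In a functional assay on KB cells (Homo sapiens) for inhibition (a lower number here means a stronger inhibitor, a higher number a weaker inhibitor), compound 3 gives only a limit, > 100000 nM. It shares that position with the other two compounds: the limit of > 100000 nM in this assay, at which 3 of the 3 values shown sit.

Compound 4 `COc1ccc(Cn2c(Br)nc3cc(Cl)c(Cl)cc32)cc1` differs from compound 3 by one change, methoxy in place of hydrogen on an aromatic carbon.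

The same change has been made once before, and the result is a step that the two limits leave unreadable from compound 1 to compound 2. The bromo for chloro swap gives a step that the two limits leave unreadable from compound 1 to compound 3. Neither step has a readable size, so neither offers a measured effect to carry over. Compound 2, which already carries the methoxy, gives a limit of > 100000 nM, so no gain is expected from this change.

The expected result is a number no higher from compound 3 to compound 4 (the limit leaves the size open), with no direction favoured. Compound 4 is expected to land near 100000 nM, most likely as a limit again. The estimated range for compound 4 runs from 30000 nM to 150000 nM.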

Compound 4, half-maximal inhibitory concentration: 55000 nM
For compound 4 the middle estimate is 1.8-fold (0.26 log units) above the measured one, within the range that was stated.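

With methoxy on the six-membered aromatic ring of carbon only, para to a large group, and bromo in place of chloro, compound 4 gives 55000 nM as the first number in this assay among these compounds. The methoxy change gives an at least 1.8-fold lower number from compound 3 to compound 4 (0.25 log units; that floor lies within the scatter) and the bromo for chloro swap gives an at least 1.8-fold lower number from compound 2 to compound 4 (0.25 log units; that floor lies within the scatter), and both are only floors, set against a limit rather than a number. For the compounds shown here, neither change alone yields a number, and the earlier steps cannot be read: the limit of > 100000 nM in this assay, at which 3 of the 4 values shown sit.

Going by these compounds, the true size of each step remains open, as does how much each change contributes. Also open, on these data alone, is what an amine, a carboxylic acid or a longer chain would give in place of the methoxy.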